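The compounds below may be only part of what the source reports. "The series", "measured", "known", "first", "only" and "open" are said of these compounds alone.

Working notes on the series

Compound 1 `Nc1cc(N)c2nc(-c3ccccc3)c(Oc3ccc(Cl)c(Cl)c3)nc2c1` is the reference point here. For the measured compounds named here, in a functional assay on HCT-116 cells (Homo sapiens) for inhibition, read by sulforhodamine B assay, with a stated time of 48 h (a higher number here means a weaker inhibitor of growth, a lower number a stronger inhibitor of growth), compound 1 gives 15800 nM, the second highest of the three numbers so far. The nearest number belongs to compound 3 `Nc1cc(N)c2nc(-c3ccccc3)c(NCc3ccc(Cl)c(Cl)c3)nc2c1`, which gives 11500 nM in this assay; the gap to compound 1 lies within the scatter, so nothing is made of it. The furthest belongs to compound 2 `CCOC(=O)[C@H](CCC(=O)O)NC(=O)c1ccc(CNc2nc3cc(N)cc(N)c3nc2-c2ccccc2)cc1`, which in this assay gives 91200 nM, a higher number than compound 1 and beyond the scatter. Going by the values given here, no pair of measured compounds differs in a single place, so no measured step is available to lean on.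

Compound 4 `Nc1cc(N)c2nc(-c3ccccc3)c(Oc3ccc(F)cc3)nc2c1` has not been measured. Relative to compound 1 the change is 4-fluorophenyl in place of 3,4-dichlorophenyl on an oxygen on an aromatic ring; the same difference, cut one bond further out, reads 3,4-dichlorophenoxy to 4-fluorophenoxy. Nothing among the three measured compounds shows this swap. The expectation is therefore a step from compound 1 to compound 4 of modest size in this assay, a 1.5-fold higher number from compound 1 to compound 4 (0.18 log units; within the scatter), leaning toward a higher number but plausibly still within the scatter. On that basis compound 4 is expected to give about 24000 nM in this assay, with a range from 8000 nM to 70000 nM.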

Compound 4, concentration for 50% growth inhibition: 14800 nM
Compound 4: middle estimate off by 1.6-fold (0.21 log units), on the high side; the range from low to high includes it.
By their numbers in this assay, from the lowest: compounds 3, 4 and 1 (each within the scatter of the next); then compound 2.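

For the compounds shown here, compound 4 supplies the only measured step at this position: in this assay the change to 4-fluorophenyl in place of 3,4-dichlorophenyl on an oxygen on an aromatic ring is a 1.1-fold lower number from compound 1 to compound 4 (0.03 log units; within the scatter). Going by these compounds alone, the earlier compounds offered no single-place comparison, so this pair is the first direct reading of the position, and on it the two aryl groups cannot be told apart, even though one carries two chlorine atoms and the other one fluorine, with 8 and 7 heavy atoms. For this one pair, then, the swap of these two halogenated rings leaves no measurable separation in this growth read-out, and no independent measurement bears on how that result should be interpreted.

On these data alone, whether a plain phenyl, or a phenyl carrying an amine, a methoxy group or a carboxylic acid, on the same oxygen would also stay within the scatter of compound 1 remains open. Also open, as far as these compounds go, is whether the same aryl swap would read the same way with a nitrogen-linked benzyl group, as in compound 3.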